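The source may report more compounds than this note shows. Statements on the series, on what has been measured and on what is new or still open speak of the compounds shown alone.

Compound 1 `CCCn1c(=O)[nH]c2nc(-c3ccc(S(=O)(=O)N4CCN(c5ccc(C)cc5)CC4)cc3)[nH]c2c1=O`: in an assay on CHO cells for displacement of a labelled ligand from adenosine receptor A3 (Homo sapiens), read by scintillation counting, with a stated time of 45 min, in the presence of a further agent that is not named here (on this read-out lower numbers stand for stronger inhibition and higher numbers for weaker inhibition), compound 1 gives > 1000 nM, which is a limit of the assay.
Compound 2 `CCCn1c(=O)[nH]c2nc(-c3ccc(S(=O)(=O)N4CCN(c5cccc(F)c5)CC4)cc3)[nH]c2c1=O`: in this assay compound 2 gives > 1000 nM, likewise a limit of the assay.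

Compound 2 therefore stands at the edge of what this assay reports, with no number behind it. Among the measured compounds shown here, the one step between measured compounds, a step that the two limits leave unreadable from compound 1 to compound 2, cannot be sized, since both of its ends rest on (the limit of > 1000 nM in this assay, at which 2 of the 2 values shown sit). Compound 3 `CCCn1c(=O)[nH]c2nc(-c3ccc(S(=O)(=O)N4CCN(c5ccc(I)cc5)CC4)cc3)[nH]c2c1=O` is the compound still to be measured. It differs from compound 2 by 4-iodophenyl in place of 3-fluorophenyl on an amine nitrogen in a ring. For the measured compounds named here, the only measured step touches the same amine nitrogen in a ring, but its size is not readable, so it gives no direction for this change. Nothing in the measured pair shows that an aryl change on that nitrogen moves the value out from the limit, and compound 3 is therefore expected to sit near the limit as well. The step that the limit leaves unreadable from compound 2 to compound 3 is expected to lie within the scatter. Compound 3 is estimated at 2500 nM, with a range from 600 nM to 10000 nM.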

Compound 3, inhibition constant: > 1000 nM
Compound 3 ended at the assay's limit (the forecaster's own chance of this, stated with the estimate: 70%); the middle value does not contradict the limit.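

In this assay compound 3 gives > 1000 nM, which is a limit of the assay. No step among compound 1, compound 2 and compound 3 can be read, because all three compounds rest on the same limit: the limit of > 1000 nM in this assay, at which 3 of the 3 values shown sit.

The compounds shown leave open how far each lies from that limit, and whether any group on the amine nitrogen in a ring would give a measured number.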